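Dropping methylcarbamoyl from compound 2: a half-life estimate

A few compounds are considered here, and "the series" means these few. Any claim that something is new, unique, unknown or untested is made for them only; others in the source may bear on it.

Compound 1 `COc1cc(OCc2cccc(-c3cnc(OC)nc3)c2)c2cc(-c3cn4nc(OC)sc4n3)oc2c1` has 1.03 h as its value.
Compound 2 `CNC(=O)c1ccc(-c2nc(COc3cc(OC)cc4oc(-c5cn6nc(OC)sc6n5)cc34)cs2)cc1` has 0.517 h as its value.

These two numbers come from an ADME assay on microsomes from liver (Rattus norvegicus) for metabolic stability (on this read-out lower numbers stand for a shorter-lived compound and higher numbers for a longer-lived compound), and they are all that has been measured so far. Compound 2 stands within the usual scatter of compound 1, so the pair cannot be ranked. Compound 3 `COc1cc(OCc2csc(-c3ccccc3)n2)c2cc(-c3cn4nc(OC)sc4n3)oc2c1` differs from compound 2 in one place. The change is hydrogen in place of methylcarbamoyl on an aromatic carbon and in words it puts hydrogen in place of methylcarbamoyl on an aromatic carbon, turning 4-(methylcarbamoyl)phenyl into phenyl. Among the measured compounds shown here, no two measured compounds differ in just one place, so the data offer no direct guide to this change. The closeness of the two measured values gives no reason to expect a large move. The expected change is a 1.2-fold higher number from compound 2 to compound 3 (0.06 log units; within the scatter) and that is estimated to stay within the scatter. Compound 3 is expected at 0.6 h within a range of 0.25 h to 1.4 h on this read-out.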

Compound 3, half-life: 1.22 h
Estimate against measurement, compound 3: 2.0-fold (0.31 log units) below; low and high end bracket the measured number.
By their numbers in this assay, from the lowest: compounds 2, 1 and 3 (each within the scatter of the next, the first and the last beyond it).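

In this assay, among the compounds shown here, turning 4-(methylcarbamoyl)phenyl into phenyl gives a 2.4-fold higher number from compound 2 to compound 3 (0.37 log units; beyond the scatter), and this is the first comparison here in which only one place differs. It shows that this position of the phenyl ring can shift the half-life by more than the usual scatter, even though the step is modest. It also shows that methylcarbamoyl is not required for stability here, since compound 3, which carries only hydrogen at that place, gives 1.22 h, and no measurement at hand says what lies behind this step.

Still open, from the compounds shown here alone, is whether a carboxylic acid, an amine or a simple methyl group at the same place would give a longer or shorter half-life than hydrogen. Also open, going by these compounds, is whether removing methylcarbamoyl would have the same effect on a different core.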